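Urea in place of amide on a cytotoxicity-tolerant scaffold

The compounds below may be only part of what the source reports. "The series", "measured", "known", "first", "only" and "open" are said of these compounds alone.

Compound 1 `COc1cc(-c2nn(-c3cccc(NC(=O)Nc4ccc(Cl)c(Cl)c4)c3)cc2-c2ccncc2)ccc1Cl`: in a functional assay on NCI-H226 cells (Homo sapiens) for inhibition, read by sulforhodamine B assay, with a stated time of 48 h (a higher number here means that more compound is tolerated, a lower number that less compound is tolerated), compound 1 reaches only the limit > 50000 nM.
Compound 2 `COc1cc(-c2nn(-c3cccc(NC(=O)c4ccc(Cl)c(C(F)(F)F)c4)c3)cc2-c2ccncc2)ccc1Cl`: in this assay compound 2 reaches only the limit > 32500 nM.

Going by the values given here, compound 2 stands at a limit of the assay, and the one further value shown is a limit too the limit of > 32500 nM in this assay, at which 1 of the 2 values shown sits (the limit of > 50000 nM in this assay, at which 1 of the 2 values shown sits). The step that the two limits leave unreadable from compound 1 to compound 2 is therefore not readable in size. Compound 3 `COc1cc(-c2nn(-c3cccc(NC(=O)Nc4ccc(Cl)c(C(F)(F)F)c4)c3)cc2-c2ccncc2)ccc1Cl` differs from compound 2 by (4-chloro-3-(trifluoromethyl)phenyl)amino in place of 4-chloro-3-(trifluoromethyl)phenyl on a carbonyl carbon, an exchange that brings back the urea linkage of compound 1 while keeping the ring of compound 2. Neither measured value gives a readable step, so no movement beyond the scatter is expected, and compound 3 is estimated to sit again at the limit: a step that the limit leaves unreadable from compound 2 to compound 3, giving an estimate of 50000 nM with a range from 20000 nM to 100000 nM.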

Compound 3, concentration lethal to 50% of the cells: > 32500 nM
Compound 3: no number, only a limit; the forecaster's own chance of this, stated with the estimate: 80%; the middle value does not contradict the limit.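

Going by these compounds alone, compound 1, compound 2 and compound 3 all give only limits in this assay, and no step among them can be read. The compounds shown leave open what concentration each one actually tolerates, and whether either exchange changes it.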